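A Methyl Added to Compound 2: Expected Cytotoxicity

A few compounds are considered here, and "the series" means these few. Any claim that something is new, unique, unknown or untested is made for them only; others in the source may bear on it.

Compound 1, `CC(C)(C)Nc1c(-c2ccccn2)nc2c(OCc3ccccc3)cccn12`: > 50000 nM
Compound 2, `c1ccc(-c2nc3ccccn3c2Nc2ccc3c(c2)OCCO3)nc1`: 25600 nM

In an ADME assay on THP-1 cells (Homo sapiens) for cytotoxicity (on this read-out higher numbers stand for lower toxicity in this test and lower numbers for higher toxicity in this test), compound 1 gives only a limit, > 50000 nM, and so sits at the limit of > 50000 nM in this assay, at which 1 of the 2 values shown sits. Among the compounds with values here, compound 2 gives 25600 nM in this assay, the only actual number among the two compounds. Compound 3, `Cc1ccc2nc(-c3ccccn3)c(Nc3ccc4c(c3)OCCO4)n2c1`, differs from compound 2 by methyl in place of hydrogen on an aromatic carbon, in words methyl in place of hydrogen on an aromatic carbon. Within the data shown here, no measured pair shows what such a change does here, so the expectation is a small step, none beyond the scatter. Compound 3 is therefore expected at 22000 nM, with a range from 9000 nM to 55000 nM. That estimate means a step of a 1.2-fold lower number from compound 2 to compound 3 (0.07 log units; within the scatter).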

Compound 3, half-maximal cytotoxic concentration: 16000 nM
For compound 3 the middle estimate is 1.4-fold (0.14 log units) above the measured one; measured number inside the range.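

In this assay, within the data shown here, the swap of hydrogen for methyl gives a 1.6-fold lower number from compound 2 to compound 3 (0.20 log units; within the scatter) and provides the first measured reading for this position, on an aromatic carbon two atoms from the ring nitrogen. On this read-out, compound 2 and compound 3 cannot be told apart, so this single methyl leaves no effect that stands clear of the scatter. Nothing available here explains this result.

Going by these compounds, whether an amine, a carboxylic acid or a longer chain at this position would move the number beyond the scatter remains open. So does the outcome of placing methyl on the other carbons of that ring.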